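The compounds below may be only part of what the source reports. "The series", "measured", "known", "first", "only" and "open" are said of these compounds alone.

In a functional assay on MV4-11 cells (Homo sapiens) for antiproliferative activity, read by luminescence and CellTiter-Glo, with a stated time of 72 h (on this read-out lower numbers stand for stronger inhibition and higher numbers for weaker inhibition), compound 1 (`CNc1cc(-c2ccc3cnn(Cc4ccc(F)cc4)c3c2)cn(C)c1=O`) gives 2390 nM. Compound 2 (`CNc1cc(-c2ccc3cnn(Cc4ccc(OC)cc4)c3c2)cn(C)c1=O`) gives 2700 nM, and putting methoxy in place of fluoro amounts to a 1.1-fold higher number from compound 1 to compound 2 (0.05 log units; within the scatter). Compound 3 (`CNc1cc(-c2ccc3cnn(Cc4ccc(OC)c(F)c4)c3c2)cn(C)c1=O`) gives 4980 nM. Compound 1 therefore stands level with compound 2 and on the stronger side of compound 3, with a 2.1-fold higher number from compound 1 to compound 3 (0.32 log units; beyond the scatter).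

The next structure, compound 4 (`CCNc1cc(-c2ccc3cnn(Cc4ccc(F)cc4)c3c2)cn(C)c1=O`), differs from compound 1 in one place: methyl in place of hydrogen on a saturated chain carbon bound to a nitrogen on an aromatic ring. This puts methyl in place of hydrogen on a saturated chain carbon bound to a nitrogen on an aromatic ring, turning methylamino into ethylamino.

For the measured compounds named here, no measured step touches this place, since all three alter the 4-fluorophenyl group instead. They offer only a rough sense of scale, the last being a 1.8-fold higher number from compound 2 to compound 3 (0.27 log units; within the scatter). All three steps are small, but they cannot show how this assay responds to a change at the methylamino group. No step beyond the scatter is therefore expected, only a slight lean towards a higher number, and that lean is a cautious guess. The expected size of the change is a 1.3-fold higher number from compound 1 to compound 4 (0.10 log units; within the scatter). The estimate for compound 4 is 3000 nM, with an expected range from 1300 nM to 7000 nM.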

Compound 4, half-maximal inhibitory concentration: 5650 nM
For compound 4 the middle estimate is 1.9-fold (0.27 log units) below the measured one; low and high end bracket the measured number.
By their numbers in this assay, from the lowest: compounds 1, 2, 3 and 4 (each within the scatter of the next, the first and the last beyond it).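

Turning methylamino into ethylamino gives a 2.4-fold higher number from compound 1 to compound 4 (0.37 log units; beyond the scatter) in this assay, so this position responds to the addition of a single methyl, and the step is large enough to stand clear of the usual scatter between repeated measurements. For the compounds shown here, the earlier compounds varied only the 4-fluorophenyl group, so this is the first measured sign that the methylamino group matters as well: the step is modest, the same grade as a 2.1-fold higher number from compound 1 to compound 3 (0.32 log units; beyond the scatter), which came from a change to the aryl group. Nothing measured here explains why the added methyl goes with a higher number.

As far as these compounds go, a single step cannot show a trend, so it remains open whether a plain amino group would give a lower number than compound 1 or whether a propylamino or longer chain would raise the number further. From the compounds shown here alone, it is also open whether the same change would have a similar effect when made on compound 2 or compound 3, which carry a methoxy group on the aromatic ring in place of the 4-fluoro pattern of compound 1.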